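Acetyl to amino on the aromatic ring of compound 1

This account rests on a few compounds, and the source may have more. Where it says the series, first, only, none or still open, it means among the compounds named here.

Compound 1 `CC(=O)c1ccc2c(c1)C1CNCC2C1`, compound 2 `c1ccc(-c2cccc3c2C2CNCC3C2)cc1` and compound 3 `c1ccc(Cc2nc3cc4c(cc3o2)C2CNCC4C2)cc1` share one core and have been run in an assay on HEK293 cells for binding affinity to Neuronal acetylcholine receptor; alpha4/beta2 (Homo sapiens); a higher number here means a weaker inhibitor, a lower number a stronger inhibitor. In this assay compound 1 gives 0.17 nM, compound 2 gives 1600 nM and compound 3 gives 34 nM. Compound 1 holds the lowest of the three numbers, and its gaps to compound 3 and to compound 2 both lie beyond the usual scatter. Compound 4 `Nc1ccc2c(c1)C1CNCC2C1` differs from compound 1 by amino in place of acetyl on an aromatic carbon. Among the compounds with values here, no measured pair shows this change, so its effect is unknown; a step toward a higher number, beyond the scatter, is expected, as nothing else in the set matches compound 1 at 0.17 nM. Compound 4 is estimated at 4 nM, with a range from 0.4 nM to 40 nM, an expected step of a 24-fold higher number from compound 1 to compound 4 (1.37 log units; beyond the scatter).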

Compound 4, inhibition constant: 100 nM
Compound 4: middle estimate off by 25-fold (1.40 log units), on the low side; measured number outside the range, above it.
By their numbers in this assay, from the lowest: compound 1; then compound 3; then compound 4; then compound 2.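

In this assay, within the data shown here, this aromatic carbon proves highly sensitive to its substituent: amino in place of acetyl gives a 590-fold higher number from compound 1 to compound 4 (2.77 log units; beyond the scatter) in the first single-place comparison of the series. The change removes the double bond of the acetyl and brings in a hydrogen-bond donor, but this one pair cannot separate those differences. No measurement on hand explains the step. Open, on these data alone, is whether a propanoyl, a methyl ester or an acetamide at this carbon would stay closer to compound 1 or fall toward compound 4. Also open, as far as these compounds go, is whether a methylamino or dimethylamino group would behave like amino.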